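The source may report more compounds than this note shows. Statements on the series, on what has been measured and on what is new or still open speak of the compounds shown alone.

Measured compounds so far:

compound 2, `NCc1cc(Oc2cccc(C(=O)NCCn3cnnn3)c2)nc(C(F)(F)F)c1`: 3460 nM
compound 3, `NCc1cc(Oc2cccc(C(=O)NC[C@@H](O)CO)c2)nc(C(F)(F)F)c1`: 1920 nM
compound 1, `NCc1cc(Oc2cccc(Oc3ccccc3)c2)nc(C(F)(F)F)c1`: "not determined" (no result reported)

The measurements come from an ADME assay on the whole organism (lung, Mus musculus) for pharmacokinetics, read by LC-MS, at a dose of 30 mg/kg by the oral route; a higher number here means more compound in the circulation at the dose given, a lower number less compound in the circulation. Compound 1 stands nowhere on these numbers: for compound 1 this assay gives "not determined" (no result reported), so there is no starting value for it, and the only figures to lean on are those of compound 2 and compound 3.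

Compound 4, `NCc1cc(Oc2cccc(C(=O)N3CC[C@@H](O)C3)c2)nc(C(F)(F)F)c1`, is not yet measured. It differs from compound 1 in one place: (3-hydroxypyrrolidin-1-yl)carbonyl in place of phenoxy on an aromatic carbon. Among the compounds with values here, the only measured step that bears on this kind of change is the one from an amide carrying one polar chain to an amide carrying another, a 1.8-fold lower number from compound 2 to compound 3 (0.26 log units; within the scatter), which stayed within the scatter. Compound 4 also carries an amide on the same aromatic carbon, here closed into a ring bearing a hydroxyl, so it is expected to sit in the same region as compound 2 and compound 3 rather than far from them. Compound 4 is therefore estimated at 2500 nM, with a range from 900 nM to 7000 nM.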

Compound 4, maximal plasma concentration: 9130 nM
Estimate against measurement, compound 4: 3.7-fold (0.56 log units) below, and the stated range ends below it.
By their numbers in this assay, from the lowest: compounds 3 and 2 (each within the scatter of the next); then compound 4.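

The two earlier amides, with open chains on the carbonyl carbon, stayed within the scatter of each other in this assay, so changing the chain had shown no clear difference. Within the data shown here, compound 4 is the first to bring the amide nitrogen into a ring, as 3-hydroxypyrrolidin-1-yl, and this gives a clear difference on both comparisons (a 4.8-fold higher number from compound 3 to compound 4 (0.68 log units; beyond the scatter)) and (a 2.6-fold higher number from compound 2 to compound 4 (0.42 log units; beyond the scatter)). Both steps are modest, and nothing here explains why the ring amide gives the higher number.

The change from phenoxy to the amide cannot be read, since compound 1 gives "not determined" (no result reported) in this assay. Also open, as far as these compounds go, is whether the ring or its hydroxyl carries the step, which a plain pyrrolidin-1-yl amide without the hydroxyl, or a six-membered piperidin-1-yl amide, could help to separate.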